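This account rests on a few compounds, and the source may have more. Where it says the series, first, only, none or still open, it means among the compounds named here.

Compound 1, `CN1CCCN(CCn2ccc3ccc(Br)cc32)CC1`, was tested in an assay on HEK293 cells for binding affinity to 5-hydroxytryptamine receptor 7 (Homo sapiens), read by radioligand binding, tested at 1 uM (on this read-out higher numbers stand for more inhibition at the one concentration tested (going by the name of the read-out) and lower numbers for less inhibition), where compound 1 gives 93%. Compound 2, `Brc1ccc2ccn(CCN3CCCN4CCCCC4C3)c2c1`, was measured in the same way, and in this assay compound 2 gives 99%. Going by the values given here, of these two numbers the one for compound 1 is the smaller, but the gap to compound 2 is within the scatter, so the two compounds cannot be told apart on this read-out. In both of them the shared core carries a bromo on a six-membered aromatic ring of carbon only; in compound 3, `CN1CCCN(CCn2ccc3ccc(C(N)=O)cc32)CC1`, that group is exchanged. The change carbamoyl in place of bromo on an aromatic carbon leaves the rest of the molecule as in compound 1. Among the compounds with values here, no measured pair shows what this exchange does, so the direction and size of the step are open and must be guessed from the structures alone. Because compound 1 already sits near the top of the read-out with 93%, the step expected for compound 3 is a number 18 percentage points lower from compound 1 to compound 3 (beyond the scatter), downward and modestly beyond the scatter. Compound 3 is thus estimated at 75%, in the range 40% to 98%.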

Compound 3, a percentage reported as inhibition, at one concentration (the size of the read-out at that concentration, not a potency): 33%
The estimate for compound 3 lay 42 percentage points above the measured number; measured number below the stated range.
By their numbers in this assay, from the lowest: compound 3; then compounds 1 and 2 (each within the scatter of the next).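

Read in this assay, this position proves far from indifferent: with the rest of the molecule held as in compound 1, carbamoyl in place of bromo on an aromatic carbon gives a number 60 percentage points lower from compound 1 to compound 3 (beyond the scatter) and takes the compound from near the top of the read-out to well down it. Compounds 1 and 2 both carry bromo at this carbon, so they could not show how much the read-out depends on the group there; this single exchange shows that the dependence is large. The step remains a difference in inhibition at one concentration rather than in potency, and as one exchange it cannot separate what leaves with bromo from what enters with carbamoyl, which brings more heavy atoms along with a hydrogen-bond donor and acceptor.

As far as these compounds go, whether chloro, methoxy or a nitrile on the same carbon would stay close to compound 1 or fall towards compound 3, and whether carbamoyl would bring a similar step on the core of compound 2, remains open. Nothing shown here gives a reason for the step.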